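This account rests on a few compounds, and the source may have more. Where it says the series, first, only, none or still open, it means among the compounds named here.

Working notes on the series.

The three measured compounds share one core and differ at the group on the aminothiazole nitrogen. Compound 1 `Clc1ccc(C(Oc2ccc3cc(Br)ccc3c2)c2cnc(NCC3CCOCC3)s2)cc1` carries a tetrahydropyranylmethyl amine; in an ADME assay on HepG2 2.2.15 cells (Homo sapiens) for cytotoxicity (a higher number here means that more compound is tolerated, a lower number that less compound is tolerated), compound 1 is recorded as "not toxic" (no number reported). Compound 2 `CC(C)(C)C(=O)Nc1ncc(C(Oc2ccc3cc(Br)ccc3c2)c2ccc(Cl)cc2)s1` carries a pivaloyl amide, and in this assay compound 2 is likewise recorded as "not toxic" (no number reported). Compound 3 `O=C(Nc1ncc(C(Oc2ccc3cc(Br)ccc3c2)c2ccc(Cl)cc2)s1)c1ccc(Br)cc1` carries a (4-bromophenyl)carbonylamino group. In this assay compound 3 reaches only a limit of the assay, > 50000 nM, and no single number is known for it; it sits at the limit of > 50000 nM in this assay, at which 1 of the 3 values shown sits, so no measured step between any two of these compounds can be stated.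

Compound 4 `Cc1noc(C)c1C(=O)Nc1ncc(C(Oc2ccc3cc(Br)ccc3c2)c2ccc(Cl)cc2)s1` is the next member. Relative to compound 3 the change is 3,5-dimethyl-1,2-oxazol-4-yl in place of 4-bromophenyl on a carbonyl carbon. With every neighbour lacking a number, no step beyond the usual scatter is expected in this assay. For compound 4 the expected value is 60000 nM, with a range from 30000 nM to 120000 nM, and it is most likely to be reported only as a limit again. The step from compound 3 to compound 4 implied by this estimate is a step that the limit leaves unreadable from compound 3 to compound 4, an expectation only.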

Compound 4, half-maximal cytotoxic concentration: "not toxic" (no number reported)
Compound 4: no number reported; there is nothing to compare the estimate with.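

Among these compounds, compound 4, like compound 3, gives no single number, so no step from compound 3 to compound 4 can be read; compound 3 holds only a limit: the limit of > 50000 nM in this assay, at which 1 of the 4 values shown sits.

The concentration at which any of these compounds becomes toxic in this assay stays open.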